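A group exchange on compound 2, still unmeasured

This account rests on a few compounds, and the source may have more. Where it says the series, first, only, none or still open, it means among the compounds named here.

Compound 1 `CN(C)CCCCCn1c2c(c3ccccc31)C(=O)c1c[n+]([O-])c3ccccc3c1C2=O`: 200 nM
Compound 2 `CC1(C)OCC(Cn2cc(Cn3c4c(c5ccccc53)C(=O)c3c[n+]([O-])c5ccccc5c3C4=O)nn2)O1`: 290 nM
Compound 3 `O=C1c2c[n+]([O-])c3ccccc3c2C(=O)c2c1c1ccccc1n2CCCCN1CCCCC1`: 150 nM

In a functional assay on MCF7 cells (Homo sapiens) for cytotoxicity, read by MTT assay, with a stated time of 72 h (on this read-out higher numbers stand for weaker inhibition and lower numbers for stronger inhibition), compound 2, at 290 nM, lies within the usual scatter of both compound 1 and compound 3, so these three values cannot be told apart. Compound 4 `O=C1c2c[n+]([O-])c3ccccc3c2C(=O)c2c1c1ccccc1n2Cc1cn([C@H]2C[C@H](O)[C@@H](CO)O2)nn1` differs from compound 2 in one place: 4-hydroxy-5-(hydroxymethyl)oxolan-2-yl in place of (2,2-dimethyl-1,3-dioxolan-4-yl)methyl on an aromatic nitrogen. Among the measured compounds shown here, the only measured single-place step, a 1.3-fold lower number from compound 1 to compound 3 (0.12 log units; within the scatter), lies within the scatter, but it concerns another side chain. For the measured compounds named here, no measured compound carries 4-hydroxy-5-(hydroxymethyl)oxolan-2-yl, so this step is only a weak guide. A change beyond the scatter is therefore not expected, though a slightly higher number is allowed for. The estimated step is a 1.4-fold higher number from compound 2 to compound 4 (0.14 log units; within the scatter). Compound 4 is expected at 400 nM, with an estimated range from 150 nM to 1100 nM.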

Compound 4, half-maximal inhibitory concentration: 530 nM
Compound 4: middle estimate off by 1.3-fold (0.12 log units), on the low side; measured number inside the range.
By their numbers in this assay, from the lowest: compounds 3, 1, 2 and 4 (each within the scatter of the next, the first and the last beyond it).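

On the aromatic nitrogen, exchanging (2,2-dimethyl-1,3-dioxolan-4-yl)methyl for 4-hydroxy-5-(hydroxymethyl)oxolan-2-yl in this assay gives a 1.8-fold higher number from compound 2 to compound 4 (0.26 log units; within the scatter), and this step lies within the scatter. This position therefore accepts a group with 2 hydrogen-bond donors in place of one with 0, without a difference that this assay can resolve. No measurement shown explains this result. On these data alone, it remains open whether a simple amine or a carboxylic acid on this nitrogen would move the number beyond the scatter. As far as these compounds go, the role of the 3 defined stereocentres also remains open.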